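Sulfonamide series: bromo for butyl on the anilide ring

The source may hold more compounds than are shown below. What is called first, only, known or untested is meant among the compounds shown, and "the series" means these compounds.

Measured compounds:
compound 1 `CCc1ccccc1NS(=O)(=O)c1ccc(N2CCNC2=O)cc1`, 350 nM
compound 2 `CCCCc1ccc(NS(=O)(=O)c2ccc(N3CCNC3=O)cc2)cc1`, 770 nM

In a functional assay on MCF7 cells (Homo sapiens) for antiproliferative activity, read by sulforhodamine B assay, with a stated time of 48 h (a lower number here means a stronger inhibitor, a higher number a weaker inhibitor), compound 1 gives 350 nM and compound 2 gives 770 nM. Among the compounds with values here, compound 2 therefore stands at the higher of the two numbers measured so far, and the gap to compound 1 lies beyond the usual scatter. Within the data shown here, the two compounds differ in more than one place, so their values are taken only as they stand, with no single step between them.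

Compound 3 `O=C1NCCN1c1ccc(S(=O)(=O)Nc2ccc(Br)cc2)cc1` is not yet measured. It differs from compound 2 by bromo in place of butyl on an aromatic carbon. The change removes the butyl chain and puts bromo on the same aromatic carbon. Among the measured compounds shown here, no measured pair in this set isolates such a change, so its effect in this assay is unknown from the data.

The expectation for compound 3 is a step of a 1.5-fold lower number from compound 2 to compound 3 (0.19 log units; within the scatter), that is a number not far from compound 2 and likely within or only just beyond the scatter. Compound 3 is expected to give 500 nM, with a range from 200 nM to 1500 nM.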

Compound 3, half-maximal inhibitory concentration: 240 nM
Beside the measured number, compound 3's estimate is 2.1-fold (0.32 log units) above it; low and high end bracket the measured number.
By their numbers in this assay, from the lowest: compounds 3 and 1 (each within the scatter of the next); then compound 2.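

Replacing butyl with bromo on this aromatic carbon, para to a large group, gives in this assay a 3.2-fold lower number from compound 2 to compound 3 (0.51 log units; beyond the scatter), the only single-group step shown at this position; the position therefore responds to the group it carries, and the butyl chain is not required for activity at this level. The exchange on the sulfonamide nitrogen gives a 1.5-fold lower number from compound 1 to compound 3 (0.16 log units; within the scatter), so the 4-bromophenyl and 2-ethylphenyl groups cannot be told apart in this assay, even though they differ in both group and name position. No measurement shown bears on the reason for either step.

As far as these compounds go, with only butyl and bromo compared at this carbon, it remains open whether the difference follows the length of the chain or the presence of the halogen; methyl, propyl, chloro or an amine at the same carbon would help separate these possibilities. From the compounds shown here alone, it also remains open how 4-ethylphenyl on the sulfonamide nitrogen would compare, since that group would separate the identity of the group from its place on the ring.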